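The source may hold more compounds than are shown below. What is called first, only, known or untested is meant among the compounds shown, and "the series" means these compounds.

In a functional assay on HCT-116 cells (Homo sapiens) for antiproliferative activity, read by MTT assay (a lower number here means a stronger inhibitor, a higher number a weaker inhibitor), compound 1 `COc1cccc(/C=N/Nc2ncc3c(n2)n(C2CCCC2)c(=O)c(=O)n3C)c1` gives 45800 nM, and compound 2 `Cc1cc(C)c(/C=N/Nc2ncc3c(n2)n(C2CCCC2)c(=O)c(=O)n3C)c(C)c1` gives 7920 nM, a difference of a 5.8-fold lower number from compound 1 to compound 2 (0.76 log units; beyond the scatter). Compound 3 `COc1ccc(/C=N/Nc2ncc3c(n2)n(C2CCCC2)c(=O)c(=O)n3C)c(OC)c1` returns only a limit, > 100000 nM. Its steps are therefore bounds: an at least 2.1-fold higher number from compound 1 to compound 3 (0.33 log units; beyond the scatter) and an at least 12-fold higher number from compound 2 to compound 3 (1.10 log units; beyond the scatter). Compound 4 `Cn1c(=O)c(=O)n(C2CCCC2)c2nc(N/N=C/c3cccc(O)c3)ncc21` has 3-hydroxyphenyl in place of 2,4-dimethoxyphenyl on a carbon with a double bond to nitrogen. The most relevant comparison is compound 1, whose 3-methoxyphenyl gave way to 2,4-dimethoxyphenyl in an at least 2.1-fold higher number from compound 1 to compound 3 (0.33 log units; beyond the scatter), while the larger at least 12-fold higher number from compound 2 to compound 3 (1.10 log units; beyond the scatter) starts from 2,4,6-trimethylphenyl and bears less directly. A modest drop is therefore expected, with the estimated change being an at least 2.5-fold lower number from compound 3 to compound 4 (0.39 log units; beyond the scatter). For compound 4 the expected value is 40000 nM, within an estimated range of 12000 nM to 100000 nM.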

Compound 4, half-maximal inhibitory concentration: 37200 nM
The estimate for compound 4 lay 1.1-fold (0.03 log units) above the measured number, within the range that was stated.
By their numbers in this assay, from the lowest: compound 2; then compounds 4 and 1 (each within the scatter of the next). At a limit, above all of these: compound 3.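

Hydrogen in place of methyl on an oxygen on an aromatic ring leaves the result within the scatter, with a 1.2-fold lower number from compound 1 to compound 4 (0.09 log units; within the scatter), so 3-hydroxyphenyl and 3-methoxyphenyl cannot be told apart here. 3-hydroxyphenyl still falls short of 2,4,6-trimethylphenyl, with a 4.7-fold higher number from compound 2 to compound 4 (0.67 log units; beyond the scatter). It reads better than 2,4-dimethoxyphenyl, with an at least 2.6-fold lower number from compound 3 to compound 4 (0.42 log units; beyond the scatter), but that step is only a bound, since compound 3 stands at a limit: the limit of > 100000 nM in this assay, at which 1 of the 4 values shown sits.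

The compounds shown leave open how far compound 3 truly lies from the others. They also leave open how an amine or a carboxylic acid on this phenyl ring would read.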